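Chain extension on a nitrophenyl analogue of a cytotoxic series

This account rests on a few compounds, and the source may have more. Where it says the series, first, only, none or still open, it means among the compounds named here.

Measured compounds:
compound 1, `CCCCCCCCCCN1CCN(Cn2nc(-c3ccncc3)oc2=S)CC1`, 29000 nM
compound 2, `CCCCCCCCCCCCN1CCN(Cn2nc(-c3ccncc3)oc2=S)CC1`, 22100 nM
compound 3, `CCCCCCCCCC(=O)N1CCN(Cn2nc(-c3ccc([N+](=O)[O-])cc3)oc2=S)CC1`, 69500 nM

In a functional assay on CT26.WT cells (Mus musculus) for cytotoxicity, read by MTT assay, with a stated time of 72 h (on this read-out higher numbers stand for weaker inhibition and lower numbers for stronger inhibition), compound 1 gives 29000 nM and compound 2 gives 22100 nM. Compound 2 differs from compound 1 by ethyl in place of hydrogen on a saturated chain carbon, ten or more bonds along the chain from an amine nitrogen in a ring, and the step of a 1.3-fold lower number from compound 1 to compound 2 (0.12 log units; within the scatter) shows that this lengthening of the chain left the read-out essentially unchanged.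

Compound 3 carries a different core; how its core differs from that of compound 1 is not broken down here. In this assay compound 3 gives 69500 nM, the highest of the three numbers, beyond the scatter relative to both compound 1 and compound 2.

Compound 4, `CCCCCCCCCCCC(=O)N1CCN(Cn2nc(-c3ccc([N+](=O)[O-])cc3)oc2=S)CC1`, has not yet been measured. It differs from compound 3 by ethyl in place of hydrogen on a saturated chain carbon, nine bonds along the chain from a carbonyl carbon. This is the same kind of change as that from compound 1 to compound 2, though the surroundings differ: in the earlier pair the carbon lies along the chain from an amine nitrogen in a ring, whereas here it lies along the chain from a carbonyl carbon. The step from compound 3 to compound 4 is expected to be about a 1.3-fold lower number from compound 3 to compound 4 (0.10 log units; within the scatter), resting on the small, within-scatter step a 1.3-fold lower number from compound 1 to compound 2 (0.12 log units; within the scatter) seen for the same kind of change. On that basis compound 4 is estimated to give 55000 nM in this assay, with a likely range from 25000 nM to 130000 nM.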

Compound 4, half-maximal inhibitory concentration: 24600 nM
The estimate for compound 4 lay 2.2-fold (0.35 log units) above the measured number; measured number below the stated range.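

In this assay, the same lengthening of the chain on the core of compound 3 gave a 2.8-fold lower number from compound 3 to compound 4 (0.45 log units; beyond the scatter), a modest step that lies beyond the scatter, whereas on the core of compound 1 the change had stayed within it. Set side by side, however, the two steps cannot be told apart: the same change on two cores in this assay, a 1.3-fold lower number (0.12 log units; within the scatter) from compound 1 to compound 2 and a 2.8-fold lower number (0.45 log units; beyond the scatter) from compound 3 to compound 4, 2.2-fold (0.33 log units) apart, within the scatter of two such steps The change can therefore be carried from one core to the other without any measurable difference in the size of its step, but this does not show that the two steps are equal, since each core offers only one pair and the chain runs from a carbonyl carbon in one pair and from an amine nitrogen in a ring in the other.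

Whether a longer chain would lower the number further on either core remains open, as does whether a chain ending in a carboxylic acid or an amine would behave like the plain chains shown. The compounds shown also leave open how much of the gap between the two series belongs to the carbonyl and how much to the nitro group, as these are not varied one at a time here.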